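Anilino Swap on a Shared Core, Before the Readout

The compounds below may be only part of what the source reports. "The series", "measured", "known", "first", "only" and "open" are said of these compounds alone.

Measured compounds:
compound 1, `Cc1n[nH]c2ccc(-c3nc4cnc(N5CCN(C)CC5)cn4c3Nc3ccccc3F)cc12`: 0%
compound 2, `Cc1n[nH]c2ccc(-c3nc4cnc(N5CCN(C)CC5)cn4c3Nc3cccc(Cl)c3)cc12`: "not determined" (no result reported)

In a functional assay on CWR22R cells (Homo sapiens) for inhibition, with a stated time of 120 h, tested at 10 uM (on this read-out higher numbers stand for more inhibition at the one concentration tested (going by the name of the read-out) and lower numbers for less inhibition), compound 1 gives 0%. Within the data shown here, compound 2 belongs to the same series, yet in this assay compound 2 gives "not determined" (no result reported), so compound 2 stands without a number; the only measured anchor is compound 1, which shares its core with compound 2. Compound 3 `COc1ccc(Nc2c(-c3ccc4[nH]nc(C)c4c3)nc3cnc(N4CCN(C)CC4)cn23)cc1` differs from compound 2 in one place: 4-methoxyphenyl in place of 3-chlorophenyl on a nitrogen on an aromatic ring. Among the measured compounds shown here, with no result for compound 2, no step from compound 2 to compound 3 can be read. The expectation for compound 3 therefore rests on compound 1, which gave 0% in this assay, and the writer expects compound 3 to stay low as well, with any difference from compound 1 lying within the scatter rather than beyond it. Compound 3 is expected to give 8%, in an estimated range from 0% to 35%.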

Compound 3, a percentage reported as inhibition, at one concentration (the size of the read-out at that concentration, not a potency): 0%
Compound 3: middle estimate off by 8 percentage points, on the high side; the range from low to high includes it.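

In this assay, there is no change at the digits printed from compound 1 to compound 3 (within the scatter) when 4-methoxyphenyl takes the place of 2-fluorophenyl on a nitrogen on an aromatic ring. Compound 1 alone gave a single reading tied to one substituent, whereas this pair shows the same printed result for two differently substituted phenyl groups on the shared core, one of them bearing a hydrogen-bond acceptor that the other lacks. Nothing available here explains this result.

The step from compound 2 to compound 3 cannot be read, so the 3-chlorophenyl group adds nothing to the comparison. Still open, on these data alone, is whether a different group on this nitrogen, such as a phenyl ring carrying an amine or a carboxylic acid, or a cyclohexyl group in place of the phenyl ring, would give a reading beyond the scatter.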